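The source may hold more compounds than are shown below. What is called first, only, known or untested is meant among the compounds shown, and "the series" means these compounds.

Measured so far in a functional assay on ECa-109 cells (Homo sapiens) for antiproliferative activity, read by MTT assay, with a stated time of 48 h; on this read-out lower numbers stand for stronger inhibition and higher numbers for weaker inhibition:
- compound 1 `CN(C)CCCn1nc(C2=C(c3cn(C)c4ccccc34)C(=O)NC2=O)c2cccnc21`: > 100000 nM
- compound 2 `Cn1cc(C2=C(c3nn(CCCn4ccnc4)c4ncccc34)C(=O)N(c3ccccc3)C2=O)c2ccccc21`: 1440 nM
- compound 3 `Cn1cc(C2=C(c3nn(CCCCn4ccnc4)c4ncccc34)C(=O)NC2=O)c2ccccc21`: 23500 nM

The result of compound 1 is a limit of this assay, not a number (the limit of > 100000 nM in this assay, at which 1 of the 3 values shown sits). Going by the values given here, compound 3 has the higher of the two numbers; compound 2 gives the lower one, but the two structures differ in more than one place, so no single step links them. Among the compounds with values here, the one step measured, an at least 4.2-fold lower number from compound 1 to compound 3 (0.62 log units; beyond the scatter), concerns a different change and does not bear on the move to compound 4 `Cn1cc(C2=C(c3nn(CCCCn4ccnc4)c4ncccc34)C(=O)N(c3ccccc3)C2=O)c2ccccc21`, which carries phenyl in place of hydrogen on an amide-type nitrogen in a ring. The values of compound 2 and compound 3 suggest a lower number after this change, though nothing measured isolates it. Compound 4 is therefore expected to give 3000 nM (range 800 nM to 12000 nM), a step of a 7.8-fold lower number from compound 3 to compound 4 (0.89 log units; beyond the scatter).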

Compound 4, half-maximal inhibitory concentration: 7540 nM
Compound 4: the middle estimate sits 2.5-fold (0.40 log units) below what was measured; measured number inside the range.
By their numbers in this assay, from the lowest: compound 2; then compound 4; then compound 3. At a limit, above all of these: compound 1.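

In this assay there is a 3.1-fold lower number from compound 3 to compound 4 (0.49 log units; beyond the scatter) when phenyl replaces the amide hydrogen, so this amide-type nitrogen accepts the added ring, and that change is now read on its own. With the phenyl present, the chain also matters: there is a 5.2-fold higher number from compound 2 to compound 4 (0.72 log units; beyond the scatter) with (1H-imidazol-1-yl)methyl in place of 1H-imidazol-1-yl. Nothing measured here explains either step. As far as these compounds go, whether a methyl or a benzyl on that nitrogen would match phenyl remains open, as does what phenyl would do for the dimethylamino chain of compound 1, whose result is a limit.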